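Swapping the sulfonyl substituent in a hydroxamate series

This account rests on a few compounds, and the source may have more. Where it says the series, first, only, none or still open, it means among the compounds named here.

Of the compounds shown here, two have been measured in an assay on isolated protein for inhibition of matrix metalloproteinase-9 (Homo sapiens); on this read-out higher numbers stand for weaker inhibition and lower numbers for stronger inhibition. Compound 1 `Cc1ccc(Oc2ccc(N(CC(=O)NO)S(C)(=O)=O)cc2)cc1` gives 31 nM. Compound 2 `Cc1ccc(Oc2ccc(N(C[C@H](O)C(=O)NO)S(=O)(=O)c3ccccc3)cc2)cc1` gives 344 nM, the higher of the two numbers, so on this read-out compound 2 is the weaker inhibitor; compound 1 and compound 2 differ in more than one place, so no single structural cause can be read from that gap.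

Compound 3 `Cc1ccc(Oc2ccc(N(C[C@H](O)C(=O)NO)S(=O)(=O)N(C)C)cc2)cc1` has not yet been measured. It differs from compound 2 in one place: dimethylamino in place of phenyl on a sulfonyl sulfur, so that phenylsulfonyl becomes dimethylsulfamoyl. Within the data shown here, no measured pair in this set shows that exact exchange, so the size of the step has to be guessed. Among the measured compounds shown here, the only guidance is that compound 1, which carries a smaller group on its sulfonyl sulfur, gives 31 nM, but it also differs elsewhere from compound 2.

Compound 3 is therefore expected to land near compound 2, with a modest move toward a lower number at most, a step of a 1.7-fold lower number from compound 2 to compound 3 (0.24 log units; within the scatter). The estimate for compound 3 in this assay is 200 nM, within a range from 60 nM to 700 nM.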

Compound 3, half-maximal inhibitory concentration: 243 nM
Compound 3: middle estimate off by 1.2-fold (0.08 log units), on the low side, within the range that was stated.
By their numbers in this assay, from the lowest: compound 1; then compounds 3 and 2 (each within the scatter of the next).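

On the sulfonyl sulfur whose other neighbour is the sulfonamide nitrogen, replacing phenyl with dimethylamino gives, in this assay, a 1.4-fold lower number from compound 2 to compound 3 (0.15 log units; within the scatter), so this pair cannot be told apart on this read-out. In this one pair, a group of 3 heavy atoms with no ring takes the place of a six-membered aromatic ring of 6 heavy atoms, and the number does not move beyond the usual scatter, so the ring is not needed to keep the reading at this level. Nothing measured here offers an explanation for this result.

The compounds shown leave open whether the same holds for other groups on this sulfur, such as a morpholine ring, a pyridine ring or a longer chain, any of which might move the number beyond the scatter. On these data alone, compound 1 differs from both of the others in more than one place, so its steps to them cannot be read, and how much of its separation from them belongs to the group on the sulfonyl sulfur remains unknown.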